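The source may hold more compounds than are shown below. What is called first, only, known or untested is meant among the compounds shown, and "the series" means these compounds.

Compound 3 `CN(C)c1ncnc2[nH]cc(Sc3cccs3)c12` is one of three close relatives that share a core and differ only in the group on one aromatic carbon: compound 1 `Cc1ncnc2[nH]cc(Sc3cccs3)c12` carries a methyl there, compound 2 `COc1ncnc2[nH]cc(Sc3cccs3)c12` a methoxy, and compound 3 a dimethylamino. In a functional assay on HL-60 cells (Homo sapiens) for cytotoxicity, read by XTT assay, with a stated time of 6 days (a higher number here means a weaker inhibitor, a lower number a stronger inhibitor), compound 1 gives > 25000 nM, which is a limit of the assay rather than a number. Compound 2 also gives only a limit, > 25000 nM. Compound 3 too reaches only a limit, > 25000 nM. Because all three values sit at the same limit (the limit of > 25000 nM in this assay, at which 3 of the 3 values shown sit), none of the three steps can be read: a step that the two limits leave unreadable from compound 1 to compound 2, a step that the two limits leave unreadable from compound 1 to compound 3 and a step that the two limits leave unreadable from compound 2 to compound 3 all remain of unknown size. Compound 4 `c1csc(Sc2c[nH]c3ncnc(-c4cccs4)c23)c1` differs from compound 3 by thiophen-2-yl in place of dimethylamino on an aromatic carbon. Going by the values given here, no measured step bears on this change; every comparison among the measured compounds is hidden by the limit. It is therefore expected that compound 4 gives 20000 nM, within 4000 nM to 60000 nM. The expected step from this estimate is an at least 1.2-fold lower number from compound 3 to compound 4 (0.09 log units; that floor lies within the scatter), most likely again reported only as a limit.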

Compound 4, half-maximal inhibitory concentration: 21100 nM
Beside the measured number, compound 4's estimate is 1.1-fold (0.02 log units) below it, within the range that was stated.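

Going by these compounds alone, with thiophen-2-yl on this aromatic carbon, compound 4 is the only one of the four compounds in this assay that gives a number rather than a limit, 21100 nM. The change gives an at least 1.1-fold lower number from compound 3 to compound 4 (0.07 log units; that floor lies within the scatter), and from the other two groups it gives an at least 1.1-fold lower number from compound 2 to compound 4 (0.07 log units; that floor lies within the scatter) and an at least 1.1-fold lower number from compound 1 to compound 4 (0.07 log units; that floor lies within the scatter). Each of these is only a floor within the scatter, so the position carries a ring with a readable value, but no real gain in strength over dimethylamino, methoxy or methyl is established.

As far as these compounds go, the steps among compound 1, compound 2 and compound 3 still cannot be read, because all three values are limits: the limit of > 25000 nM in this assay, at which 3 of the 4 values shown sit. Whether a phenyl ring or a furan-2-yl ring on this carbon would give a lower number than compound 4 stays open.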